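The compounds below may be only part of what the source reports. "The series", "measured", "known", "first", "only" and "open" are said of these compounds alone.

In a functional assay on PCO3 cells (Homo sapiens) for cytotoxicity, read by sulforhodamine B assay (on this read-out higher numbers stand for weaker inhibition of growth and lower numbers for stronger inhibition of growth), compound 1 (`CC1=CC[C@@H]([C@@](C)(O)CCCC(C)(C)NC=S)CC1`) gives 11000 nM, compound 2 (`CC1=CC[C@@H]([C@@](C)(O)CCCC(C)(C)NC(=S)NN)CC1`) gives 26800 nM, and compound 3 (`CC1=CC[C@@H]([C@@](C)(O)CCCC(C)(C)NC(=S)N/N=C\c2ccc(O)cc2)CC1`) gives 6230 nM. Compound 3 therefore stands within the scatter of compound 1 and clearly on the low side of compound 2. Compound 4 (`CC1=CC[C@@H]([C@@](C)(O)CCCC(C)(C)NC(=S)N/N=C\c2ccc([N+](=O)[O-])cc2)CC1`) has nitro in place of hydroxy on an aromatic carbon, para to a large group: nitro in place of hydroxy on an aromatic carbon. For the measured compounds named here, two measured steps bear on this only indirectly: a 2.4-fold higher number from compound 1 to compound 2 (0.39 log units; beyond the scatter) and a 4.3-fold lower number from compound 2 to compound 3 (0.63 log units; beyond the scatter). The second brings in the aromatic ring, but neither step varies the group on that ring, so no change beyond the scatter is expected in this assay. The expected step is a 1.0-fold lower number from compound 3 to compound 4 (0.02 log units; within the scatter). Compound 4 is estimated at 6000 nM, with an expected range of 2500 nM to 14000 nM.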

Compound 4, concentration for 50% growth inhibition: 18100 nM
The estimate for compound 4 lay 3.0-fold (0.48 log units) below the measured number; measured number outside the range, above it.
By their numbers in this assay, from the lowest: compounds 3, 1, 4 and 2 (each within the scatter of the next, the first and the last beyond it).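

The group on the aromatic ring does count in this assay: nitro in place of hydroxy gives a 2.9-fold higher number from compound 3 to compound 4 (0.46 log units; beyond the scatter), so this position, para to a large group, does not tolerate every replacement equally. The earlier steps shown here brought the ring in but never varied what it carries. No measurement at hand gives a reason for this shift.

For the compounds shown here, only two groups at this position can be compared, and a single step gives no trend. On these data alone, whether an amine, a methoxy group or a carboxylic acid there would give a number closer to compound 3 or to compound 4 stays open.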